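Swapping a Methoxypiperidine for a Pyridylpiperazine: Expected Solubility

This account rests on a few compounds, and the source may have more. Where it says the series, first, only, none or still open, it means among the compounds named here.

Compound 1 `COc1ccc2[nH]c(C(=O)N3CC(=O)N(Cc4ccccc4)[C@@H](CN4CCC(OC)CC4)C3)cc2c1` was measured in a physicochemical assay for solubility, read by spectrophotometry, in phosphate buffer, with a stated time of 2 h, at pH 7.4; a higher number here means a more soluble compound, a lower number a less soluble compound. In this assay compound 1 reaches only the limit > 25000 nM, so its true number is not known. Compound 2 `COc1ccc2[nH]c(C(=O)N3CC(=O)N(Cc4ccccc4)[C@@H](N4[C@H](C)CCC[C@@H]4C)C3)cc2c1` gives 100000 nM in this assay, and compound 3 `COc1ccc2[nH]c(C(=O)N3CC(=O)N(Cc4ccccc4)[C@@H](N4CCc5ccccc54)C3)cc2c1` gives 7000 nM. The step that the limit leaves unreadable from compound 1 to compound 2 cannot be read, while the steps of an at least 3.5-fold lower number from compound 1 to compound 3 (0.55 log units; beyond the scatter) and a 14-fold lower number from compound 2 to compound 3 (1.15 log units; beyond the scatter) show that exchanging the whole group on the saturated ring carbon can lower solubility considerably. Compound 4 `COc1ccc2[nH]c(C(=O)N3CC(=O)N(Cc4ccccc4)[C@@H](CN4CCN(c5ccccn5)CC4)C3)cc2c1` differs from compound 1 by 4-(pyridin-2-yl)piperazin-1-yl in place of 4-methoxypiperidin-1-yl on a saturated chain carbon bound to a saturated ring carbon. Going by the values given here, no measured step exchanges a group at that chain carbon, so none of the steps seen speaks directly to this change. Compound 4 is expected to give 15000 nM, between 4000 nM and 60000 nM. The step of an at least 1.6-fold lower number from compound 1 to compound 4 (0.22 log units; that floor lies within the scatter) is therefore only an expectation.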

Compound 4, solubility: 30200 nM
Beside the measured number, compound 4's estimate is 2.0-fold (0.30 log units) below it, within the range that was stated.
By their numbers in this assay, from the lowest: compound 3; then compound 4; then compound 2.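

The step from compound 1 to compound 4 cannot be read, because compound 1 stands only at a limit: the limit of > 25000 nM in this assay, at which 1 of the 4 values shown sits.

The compounds shown leave open whether exchanging 4-methoxypiperidin-1-yl for 4-(pyridin-2-yl)piperazin-1-yl moves the number at all, and in which direction.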